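Moving the Pyrazole Attachment Point: Clearance Expectation for Compound 3

This account rests on a few compounds, and the source may have more. Where it says the series, first, only, none or still open, it means among the compounds named here.

This account follows two isomeric compounds of one shared core and sets out what is expected for a third. Compound 1 `Cn1ccc(-c2cn3nccc3c(-c3cnn([C@]4(CC#N)C[C@@H](C#N)C4)c3)n2)n1` was measured in an ADME assay on microsomes from liver (Homo sapiens) for pharmacokinetics; a higher number here means faster removal of the compound, a lower number slower removal; its result is a limit of the assay, < 8 uL/min. Among the compounds with values here, compound 2 `N#CC[C@]1(n2cc(-c3nc(-c4cn[nH]c4)cn4nccc34)cn2)C[C@H](C#N)C1` gives 19 uL/min in this assay, the only number among the values shown. Between them, one change on an aromatic carbon, 1H-pyrazol-4-yl in place of 1-methyl-1H-pyrazol-3-yl, goes with an at least 2.3-fold higher number from compound 1 to compound 2 (0.37 log units; beyond the scatter).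

Compound 3 `N#CC[C@]1(n2cc(-c3nc(-c4cc[nH]n4)cn4nccc34)cn2)C[C@H](C#N)C1` differs from compound 2 only in this way: 1H-pyrazol-3-yl in place of 1H-pyrazol-4-yl on an aromatic carbon. Within the data shown here, the one measured step bears on it only loosely, since it altered both the methyl group and the attachment point at once, and no step isolates the attachment point alone. The number for compound 3 is therefore expected to stay near that of compound 2, with an expected step of a 1.3-fold lower number from compound 2 to compound 3 (0.10 log units; within the scatter). The estimate for compound 3 is 15 uL/min, between 6 uL/min and 35 uL/min.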

Compound 3, intrinsic clearance in a liver preparation (reported as CLH), per the amount of preparation that the assay uses: < 8 uL/min
Compound 3: no number, only a limit; the forecaster's own chance of this, stated with the estimate: 25%; middle value at least 1.8-fold (0.27 log units) away from the limit.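

In this assay, moving the pyrazole attachment point alone, from 1H-pyrazol-4-yl to 1H-pyrazol-3-yl on the aromatic carbon next to the ring nitrogen, gives an at least 2.3-fold lower number from compound 2 to compound 3 (0.37 log units; beyond the scatter). The earlier step changed the methyl group and the attachment point together, whereas this one isolates the attachment point, and at this position that change alone goes beyond the scatter. The result for compound 3, < 8 uL/min, is a limit of the assay and not a number.

Going by these compounds, whether an imidazolyl or a triazolyl ring on the same aromatic carbon would also reach the limit in this assay remains open. The step from compound 1 to compound 3, hydrogen in place of methyl on an aromatic nitrogen, cannot be read, and the full size of the drop from compound 2 also stays unknown: the limit of < 8 uL/min in this assay, at which 2 of the 3 values shown sit.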